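A Chlorobenzyl Swap in a Tight Three-Compound Group

A few compounds are considered here, and "the series" means these few. Any claim that something is new, unique, unknown or untested is made for them only; others in the source may bear on it.

In a functional assay on MDA-MB-231 cells (Homo sapiens) for cytotoxicity, read by MTT assay, with a stated time of 72 h (on this read-out lower numbers stand for stronger inhibition and higher numbers for weaker inhibition), compound 1 `CCN(CC)Cc1ccc2nc(NC(=O)N/N=C/c3cn(Cc4ccc(C(C)(C)C)cc4)c4ccccc34)sc2c1` gives 2120 nM while compound 2 `CCN(CC)Cc1ccc2nc(NC(=O)N/N=C/c3cn(Cc4ccc(C)cc4)c4ccccc34)sc2c1` gives 2010 nM and compound 3 `Cc1ccc(Cn2cc(/C=N/NC(=O)Nc3nc4ccc(CN(C)C)cc4s3)c3ccccc32)cc1` gives 1220 nM on the same read-out. Compound 2 stands within the scatter of both other compounds, so the three numbers form one tight group. Compound 4 `CCN(CC)Cc1ccc2nc(NC(=O)N/N=C/c3cn(Cc4ccccc4Cl)c4ccccc34)sc2c1` has not yet been measured. It departs from compound 2 in a single place, 2-chlorophenyl in place of 4-methylphenyl on a saturated chain carbon bound to an aromatic nitrogen and this turns 4-methylbenzyl into 2-chlorobenzyl.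

For the measured compounds named here, two measured steps bear on this change. The closer one is a 1.1-fold lower number from compound 1 to compound 2 (0.02 log units; within the scatter) and it exchanged tert-butyl for methyl on the same aromatic ring that is altered here. The other, a 1.6-fold lower number from compound 2 to compound 3 (0.22 log units; within the scatter) sits at a different part of the molecule and bears on the change only loosely. Going by the values given here, no compound carrying chlorine has been measured, so the data offer no direct reading of this exchange. Neither step leaves the scatter, and none beyond the scatter is expected here in this assay either. The estimated change is a 1.1-fold lower number from compound 2 to compound 4 (0.02 log units; within the scatter) and it is expected to stay small. Compound 4 is expected at 1900 nM with an estimated range from 1000 nM to 3600 nM as its likely span.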

Compound 4, half-maximal inhibitory concentration: 900 nM
For compound 4 the middle estimate is 2.1-fold (0.32 log units) above the measured one, outside the stated range (below it).
By their numbers in this assay, from the lowest: compounds 4, 3, 2 and 1 (each within the scatter of the next, the first and the last beyond it).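

The ring on the saturated chain carbon bound to an aromatic nitrogen now proves able to shift the number in this assay, where the exchange of 4-methylphenyl for 2-chlorophenyl gives a 2.2-fold lower number from compound 2 to compound 4 (0.35 log units; beyond the scatter) and the exchange of 4-(tert-butyl)phenyl for 2-chlorophenyl gives a 2.4-fold lower number from compound 1 to compound 4 (0.37 log units; beyond the scatter) in the same direction. The earlier change on this ring, a 1.1-fold lower number from compound 1 to compound 2 (0.02 log units; within the scatter), had suggested no such sensitivity, so the two substituents at the 4-position of the phenyl ring gave no sign of what the 2-chlorophenyl group would do. Nothing shown accounts for the shift, and no measurement offers a reason for it.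

The exchange alters both the substituent and its printed place on the ring at once, so the compounds shown cannot say whether the chlorine or its place carries the step; 4-chlorophenyl and 2-methylphenyl would separate the two. From the compounds shown here alone, it also remains open whether 2-chlorophenyl would give a similar step alongside the dimethylamino group of compound 3, or whether 2-fluorophenyl or 2-methoxyphenyl would act as 2-chlorophenyl does.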